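The source may hold more compounds than are shown below. What is called first, only, known or untested is meant among the compounds shown, and "the series" means these compounds.

In a physicochemical assay for solubility, read by LC-MS, in phosphate buffer, with a stated time of 24 h, at pH 7.4 (a higher number here means a more soluble compound, a lower number a less soluble compound), compound 3 `CN(C)C(=O)c1cc(-c2cnc(NCc3c(F)ccc4c3CCO4)c3cn[nH]c(=O)c23)n(C)n1` gives 3000 nM, level with compound 2 `Cc1nc(CO)ccc1-c1cnc(NCc2c(F)ccc3c2CCO3)c2cn[nH]c(=O)c12` at 3000 nM. Compound 1 `Cn1cc(-c2cnc(NCc3c(F)ccc4c3CCO4)c3cn[nH]c(=O)c23)cn1` lies lower at 1000 nM. Compound 4 `CNC(=O)c1ccc(-c2cnc(NCc3c(F)ccc4c3CCO4)c3cn[nH]c(=O)c23)c(C)n1` differs from compound 3 in one place: 2-methyl-6-(methylcarbamoyl)pyridin-3-yl in place of 3-(dimethylcarbamoyl)-1-methyl-1H-pyrazol-5-yl on an aromatic carbon. It carries 2-methyl-6-(methylcarbamoyl)pyridin-3-yl in place of 3-(dimethylcarbamoyl)-1-methyl-1H-pyrazol-5-yl on an aromatic carbon. The nearest measured precedent is no change at the digits printed from compound 2 to compound 3 (within the scatter), which exchanged the same two ring types in the reverse direction and stayed within the scatter. The modest steps of a 3.0-fold higher number from compound 1 to compound 2 (0.48 log units; beyond the scatter) and a 3.0-fold higher number from compound 1 to compound 3 (0.48 log units; beyond the scatter) both reached the same number. The expected step is a 1.2-fold lower number from compound 3 to compound 4 (0.08 log units; within the scatter), estimated to stay within the scatter. For compound 4 the estimate is 2500 nM, with an expected range from 900 nM to 7000 nM.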

Compound 4, solubility: 19000 nM
Estimate against measurement, compound 4: 7.6-fold (0.88 log units) below; measured number outside the range, above it.
By their numbers in this assay, from the lowest: compound 1; then compounds 2 and 3 (each within the scatter of the next); then compound 4.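

At this position, on the six-membered aromatic ring of the shared core, the number in this assay can rise well past the level shared by compound 2 and compound 3 (a 6.3-fold higher number from compound 3 to compound 4 (0.80 log units; beyond the scatter)). Methylcarbamoyl in place of hydroxymethyl alone gives a step beyond the scatter (a 6.3-fold higher number from compound 2 to compound 4 (0.80 log units; beyond the scatter)), and the whole exchange for 1-methyl-1H-pyrazol-4-yl is large (a 19-fold higher number from compound 1 to compound 4 (1.28 log units; beyond the scatter)). Nothing available here explains the rise. Going by these compounds, whether a carboxylic acid, an amine or a longer chain in place of methylcarbamoyl would hold this number stays open.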